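This account rests on a few compounds, and the source may have more. Where it says the series, first, only, none or still open, it means among the compounds named here.

Measured so far:
compound 1 `C=CC(C)(C)c1[nH]c2ccc(CC=C(C)C)c(CC=C(C)C)c2c1C[C@@H]1NC(=O)[C@H](C)NC1=O`: 623000 nM
compound 2 `C=CC(C)(C)c1[nH]c2ccc(C[C@@H](O)C(C)(C)O)cc2c1/C=C1\NC(=O)[C@H](C)NC1=O`: 79000 nM
compound 3 `C=CC(C)(C)c1[nH]c2ccc(CC=C(C)C)c(CC=C(C)C)c2c1/C=c1\[nH]c(=O)c(=C)[nH]c1=O`: 51000 nM

In a functional assay (on this read-out lower numbers stand for stronger inhibition and higher numbers for weaker inhibition), compound 3 gives the lowest of the three numbers. Its nearest neighbour is compound 2, whose value lies within the usual scatter of that of compound 3, so the two cannot be told apart. Within the data shown here, compound 1 stands much further away, and the one step measured in one place, a 12-fold lower number from compound 1 to compound 3 (1.09 log units; beyond the scatter), is large and beyond the scatter.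

Compound 4 `C=CC(C)(C)c1[nH]c2ccc(CC=C(C)C)cc2c1/C=c1\[nH]c(=O)c(=C)[nH]c1=O` has not yet been measured. It differs from compound 3 in one place: hydrogen in place of 3-methylbut-2-en-1-yl on an aromatic carbon. Among the measured compounds shown here, no measured step touches this kind of change; the step from compound 1 to compound 3 concerns a different part of the molecule, and compound 2, which carries a different side group in a related region, gives a number within the scatter of compound 3 in this assay. With nothing pointing in either direction, the expectation is a step that stays within the scatter, a 1.2-fold higher number from compound 3 to compound 4 (0.07 log units; within the scatter). For compound 4 the estimated value in this assay is 60000 nM, with a range from 20000 nM to 180000 nM.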

Compound 4, half-maximal inhibitory concentration: 60000 nM
For compound 4 middle estimate and measured number coincide at the digits printed; the measured number falls inside the stated range.
By their numbers in this assay, from the lowest: compounds 3, 4 and 2 (each within the scatter of the next); then compound 1.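

In this assay, hydrogen in place of 3-methylbut-2-en-1-yl on this aromatic carbon gives a 1.2-fold higher number from compound 3 to compound 4 (0.07 log units; within the scatter), so the two compounds cannot be told apart. Among these compounds, this is the first direct look at this position, and it shows that this assay does not detect the loss of this five-carbon chain when the other 3-methylbut-2-en-1-yl group stays in place. No measurement shown here gives a reason for this result.

As far as these compounds go, with only hydrogen and 3-methylbut-2-en-1-yl compared at this carbon, the effect of an amine, a carboxylic acid or a longer chain there remains open. Also open, from the compounds shown here alone, is whether the remaining 3-methylbut-2-en-1-yl group matters, and whether the same swap would behave alike with the non-aromatic ring of compound 1.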